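The compounds below may be only part of what the source reports. "The series", "measured", "known", "first", "only" and "open" are said of these compounds alone.

Measured so far:
- compound 1, `Cc1ccc(NC2=CC(=O)c3c(nc4n3[C@H]3OC[C@@H](O)[C@H]3OC4)C2=O)cc1C`, 1050 nM
- compound 2, `CCOc1ccc(NC2=CC(=O)c3c(nc4n3[C@H]3OC[C@@H](O)[C@H]3OC4)C2=O)cc1`, 2090 nM
- compound 3, `CCc1ccc(NC2=CC(=O)c3nc4n(c3C2=O)[C@H]2OC[C@@H](O)[C@H]2OC4)cc1`, 1290 nM

All three numbers come from a functional assay on MGC-803 cells (Homo sapiens) for inhibition, read by sulforhodamine B assay; on this read-out higher numbers stand for weaker inhibition and lower numbers for stronger inhibition. The three sit close together: compound 3 stands second highest, with compound 1 its nearest neighbour and compound 2 its furthest, and both of those gaps fall within the usual scatter, so no order among the three can be read from them.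

For the measured compounds named here, the one single-place step measured in this assay is a 2.0-fold higher number from compound 1 to compound 2 (0.30 log units; within the scatter), a swap of one aryl group for another on the amine nitrogen that did not move the number beyond the scatter.

Compound 4, `COc1ccccc1NC1=CC(=O)c2nc3n(c2C1=O)[C@H]1OC[C@@H](O)[C@H]1OC3`, is the next step from compound 3. Its change: 2-methoxyphenyl in place of 4-ethylphenyl on an amine nitrogen. Going by the values given here, this is again a swap of one aryl group for another on the same amine nitrogen, so the step from compound 1 to compound 2 is the only measured step that bears on it, and it was flat. Among the compounds with values here, nothing among the measured compounds argues for a shift beyond the scatter in either direction, so the step of a 1.2-fold higher number from compound 3 to compound 4 (0.07 log units; within the scatter) is expected to stay within it.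

Compound 4 is therefore estimated at 1500 nM in this assay, with a range of 600 nM to 4000 nM.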

Compound 4, half-maximal inhibitory concentration: 1630 nM
Beside the measured number, compound 4's estimate is 1.1-fold (0.04 log units) below it; measured number inside the range.
By their numbers in this assay, from the lowest: compounds 1, 3, 4 and 2 (each within the scatter of the next).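

In this assay, a 1.3-fold higher number from compound 3 to compound 4 (0.10 log units; within the scatter) stays within the scatter, making this the second aryl swap on the amine nitrogen to leave the number unresolved, after a 2.0-fold higher number from compound 1 to compound 2 (0.30 log units; within the scatter). The new step adds a different kind of change: the substituent's place on the aryl ring is now named 2 rather than 4, and 2-methoxyphenyl carries a hydrogen-bond acceptor where 4-ethylphenyl has none, at the same heavy-atom count. Across compound 3 and compound 4, the number therefore shows no resolved response to this combined change, and nothing at hand gives a reason for that flatness or separates the contribution of the ring place from that of the acceptor.

On these data alone, whether this amine nitrogen stays as flat with a non-aromatic group such as cyclohexyl, or with a phenyl ring carrying a carboxylic acid or a dimethylamino group, remains open. Also open, as far as these compounds go, is how the number responds to changes away from this amine nitrogen, such as an acetyl ester in place of the hydroxyl on the shared core.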